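This account rests on a few compounds, and the source may have more. Where it says the series, first, only, none or still open, it means among the compounds named here.

In a functional assay on CLL cells (Homo sapiens) for cytotoxicity, read by MTT assay, with a stated time of 48 h (a higher number here means that more compound is needed for the effect, a lower number that less compound is needed), three amides of the shared core have been measured. Compound 1 (`C=C(CC)C(=O)c1ccc(OCC(=O)Nc2ccc(C(=O)O)cn2)c(Cl)c1Cl`) gives 14900 nM and compound 2 (`C=C(CC)C(=O)c1ccc(OCC(=O)NCCCN2CCCC2=O)c(Cl)c1Cl`) gives 13800 nM, while compound 3 (`C=C(CC)C(=O)c1ccc(OCC(=O)Nc2cccc(C(=O)O)c2)c(Cl)c1Cl`) gives 20600 nM and so stands within the scatter of both. Compound 4 (`C=C(CC)C(=O)c1ccc(OCC(=O)Nc2ccc3nc[nH]c3c2)c(Cl)c1Cl`) has 1H-benzimidazol-6-yl in place of 3-carboxyphenyl on an amide-type nitrogen. Among the compounds with values here, the steps that bear on this are swaps on that same nitrogen: a 1.4-fold higher number from compound 1 to compound 3 (0.14 log units; within the scatter) and a 1.5-fold higher number from compound 2 to compound 3 (0.17 log units; within the scatter) as well as a 1.1-fold lower number from compound 1 to compound 2 (0.03 log units; within the scatter) all lie within the scatter. None of them involves 1H-benzimidazol-6-yl, but no step beyond the scatter is expected, and the estimated step is small (a 1.4-fold lower number from compound 3 to compound 4 (0.14 log units; within the scatter)). In this assay the estimate for compound 4 is 15000 nM (expected range 6000 nM to 35000 nM).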

Compound 4, half-maximal effective concentration: 3200 nM
Compound 4: middle estimate off by 4.7-fold (0.67 log units), on the high side, and the stated range ends above it.
By their numbers in this assay, from the lowest: compound 4; then compounds 2, 1 and 3 (each within the scatter of the next).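

Among the swaps on the amide-type nitrogen in this assay, the three earlier groups stayed within the scatter of one another, whereas 1H-benzimidazol-6-yl gives a step beyond it against each of them (a 6.4-fold lower number from compound 3 to compound 4 (0.81 log units; beyond the scatter); a 4.3-fold lower number from compound 2 to compound 4 (0.63 log units; beyond the scatter); a 4.7-fold lower number from compound 1 to compound 4 (0.67 log units; beyond the scatter)). This shows that the number at this position does respond to the group carried there, and that the entering five-membered aromatic ring with 2 hetero atoms accompanies the lower number. Nothing measured here explains the change.

The compounds shown leave open whether an indole, with one ring nitrogen fewer, would give a similar number. They also leave open how an amine or a carboxylic acid on the benzimidazole would alter it.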